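Series notes: fluoro to hydrogen on the carboxyphenyl ring

This account rests on a few compounds, and the source may have more. Where it says the series, first, only, none or still open, it means among the compounds named here.

Measured so far:
- compound 1 `Cc1c(OCCCCOc2cccc(C(=O)O)c2)ccc(C(=O)CC(C)C)c1C`: 18.3% in an assay on HEK293 cells for positive allosteric modulation of metabotropic glutamate receptor 3 (Rattus norvegicus), read by thallium flux, with a stated time of 2.5 min; on this read-out lower numbers stand for smaller maximal responses and higher numbers for larger maximal responses
- compound 2 `Cc1c(OCCCCOc2ccc(F)c(C(=O)O)c2)ccc(C(=O)CC(C)C)c1C`: 13.8% in this assay
- compound 3 `Cc1c(OCCCCOc2ccc(F)c(C(=O)O)c2)ccc(C(=O)CC2CCCC2)c1C`: 12.6% in this assay

All three numbers lie within the usual scatter of one another, so no order among them is claimed. Compound 4 `Cc1c(OCCCCOc2cccc(C(=O)O)c2)ccc(C(=O)CC2CCCC2)c1C` has not yet been measured in this assay. It differs from compound 3 by hydrogen in place of fluoro on an aromatic carbon. The same change has already been made once, from compound 2 to compound 1, as hydrogen in place of fluoro on an aromatic carbon, and there it gave a number 4.5 percentage points higher from compound 2 to compound 1 (within the scatter). The cores of the two pairs differ by cyclopentyl in place of isopropyl on a saturated chain carbon bound to a carbonyl carbon, a step of a number 1.2 percentage points lower from compound 2 to compound 3 (within the scatter). Since the place of the change reads the same in both pairs, the change is counted as the same, not merely the same kind.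

The step from compound 3 to compound 4 is therefore expected to be a number 4.4 percentage points higher from compound 3 to compound 4 (within the scatter), beside the earlier one, resting on compound 1 because a number 4.5 percentage points higher from compound 2 to compound 1 (within the scatter) stayed within the scatter. Compound 4 is thus expected at 17%, with a range from 8% to 26%.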

Compound 4, largest response reached (reported as percent of maximum), in percent of the reference or control that the assay uses: 16.5%
The estimate for compound 4 lay 0.5 percentage points above the measured number, within the range that was stated.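

In this assay, hydrogen in place of fluoro on the cyclopentyl core gives a number 3.9 percentage points higher from compound 3 to compound 4 (within the scatter), and this step matches the one on the isopropyl core: the same change on two cores in this assay, a number 4.5 percentage points higher (within the scatter) from compound 2 to compound 1 and a number 3.9 percentage points higher (within the scatter) from compound 3 to compound 4, 0.6 percentage points apart, within the scatter of two such steps. Read the other way round, cyclopentyl in place of isopropyl on the core without the fluoro gives a number 1.8 percentage points lower from compound 1 to compound 4 (within the scatter), and this step also matches its earlier counterpart: the same change on two cores in this assay, a number 1.2 percentage points lower (within the scatter) from compound 2 to compound 3 and a number 1.8 percentage points lower (within the scatter) from compound 1 to compound 4, 0.6 percentage points apart, within the scatter of two such steps. Going by these compounds alone, the four compounds form a closed square whose steps all lie within the scatter, so the agreement shows only that neither change moved the maximal response beyond the scatter on either core, and it does not establish an effect of either change or show that the steps would carry over to cores beyond these two.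

The compounds shown leave open whether chloro or methoxy in the place of the fluoro, or a primary amide in place of the carboxy group, would give a step beyond the scatter. They also leave open whether these steps would hold on a core with a longer chain between the two ether oxygens.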